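Swapping the oxazole on compound 2 for a tetrazolylphenyl

A few compounds are considered here, and "the series" means these few. Any claim that something is new, unique, unknown or untested is made for them only; others in the source may bear on it.

In an assay on isolated protein for activation of cGMP-dependent protein kinase 1 (Homo sapiens), read by ADP-Glo, with stated times of 120 min and 40 min (a higher number here means that more compound is needed for the effect, a lower number that less compound is needed), compound 2 `Clc1cc(Cl)cc(CO[C@H]2CCCN(Cc3ncco3)[C@H]2c2ccccc2)c1` gives only a limit of the assay, > 200000 nM. Its two neighbours differ from it only in the group on a saturated chain carbon bound to an amine nitrogen in a ring: compound 1 `Cn1cc(CN2CCC[C@H](OCc3cc(Cl)cc(Cl)c3)[C@@H]2c2ccccc2)cn1` gives 110000 nM in this assay, and compound 3 `O=C(O)c1cncc(CN2CCC[C@H](OCc3cc(Cl)cc(Cl)c3)[C@@H]2c2ccccc2)c1` gives 117000 nM. The step of an at least 1.8-fold higher number from compound 1 to compound 2 (0.25 log units; that floor lies within the scatter) and the step of an at least 1.7-fold lower number from compound 2 to compound 3 (0.23 log units; that floor lies within the scatter) both run into the limit (the limit of > 200000 nM in this assay, at which 1 of the 3 values shown sits), so neither tells how far compound 2 truly lies from its neighbours. The step of a 1.1-fold higher number from compound 1 to compound 3 (0.03 log units; within the scatter) shows that exchanging one aromatic group for another on that carbon moved the number little. Compound 4 `Clc1cc(Cl)cc(CO[C@H]2CCCN(Cc3ccc(-c4nn[nH]n4)cc3)[C@H]2c2ccccc2)c1` carries the change (4-(2H-tetrazol-5-yl)phenyl in place of 1,3-oxazol-2-yl on a saturated chain carbon bound to an amine nitrogen in a ring). Going by the values given here, since the only steps touching compound 2 are floors within the scatter, no step beyond the scatter can be expected for compound 4, and the result may again be a limit. Compound 4 is therefore expected to give roughly 150000 nM in this assay, within a range of 60000 nM to 300000 nM. That expectation corresponds to the step of an at least 1.3-fold lower number from compound 2 to compound 4 (0.12 log units; that floor lies within the scatter).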

Compound 4, half-maximal effective concentration: 74000 nM
Beside the measured number, compound 4's estimate is 2.0-fold (0.31 log units) above it; the range from low to high includes it.
By their numbers in this assay, from the lowest: compounds 4, 1 and 3 (each within the scatter of the next). At a limit, above all of these: compound 2.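

In this assay, going by these compounds alone, the 4-(2H-tetrazol-5-yl)phenyl group gives the first step on a saturated chain carbon bound to an amine nitrogen in a ring that clears the scatter, an at least 2.7-fold lower number from compound 2 to compound 4 (0.43 log units; beyond the scatter), although this is only a floor. Compound 2 remains a limit of the assay: the limit of > 200000 nM in this assay, at which 1 of the 4 values shown sits. The other two new steps are a 1.6-fold lower number from compound 3 to compound 4 (0.20 log units; within the scatter) and a 1.5-fold lower number from compound 1 to compound 4 (0.17 log units; within the scatter), so the larger group, with its two rings, stands level with 1-methyl-1H-pyrazol-4-yl and 5-carboxypyridin-3-yl at this place.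

On these data alone, how far compound 2 truly lies from the other three remains open, as does whether the tetrazole or the phenyl ring matters more for the step. A plain phenyl, or a carboxylic acid in place of the tetrazole on that phenyl, could separate the two.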